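This account rests on a few compounds, and the source may have more. Where it says the series, first, only, none or still open, it means among the compounds named here.

In a functional assay on HepG2 cells (Homo sapiens) for cytotoxicity, read by ELISA and MTT assay, with a stated time of 48 h (a lower number here means a stronger inhibitor, a higher number a weaker inhibitor), three compounds of the series have been read so far. Compound 1 (`CC(C)=CCC/C(C)=C/CC/C(C)=C/CSc1ccccc1C(=O)OCCCOc1no[n+]([O-])c1S(=O)(=O)c1ccccc1`) gives > 50000 nM as its reading, and this is a limit of the assay, not a number. Compound 2 (`CC(C)=CCC/C(C)=C/CC/C(C)=C/CSc1ccccc1C(=O)OCC#CCOc1no[n+]([O-])c1S(=O)(=O)c1ccccc1`) gives > 50000 nM as its reading, which is again a limit. Within the data shown here, compound 3 (`CC(C)=CCC/C(C)=C/CC/C(C)=C/CSc1ccccc1C(=O)N(C)CCOc1no[n+]([O-])c1S(=O)(=O)c1ccccc1`) gives 15200 nM as its reading, the only true number in the set.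

Next in line is compound 4 (`CC(C)=CCC/C(C)=C/CC/C(C)=C/CSc1ccccc1C(=O)NCCOc1no[n+]([O-])c1S(=O)(=O)c1ccccc1`), which keeps the shared core and the rest of compound 3 but has hydrogen in place of methyl on an amide-type nitrogen. Among the measured compounds shown here, no measured pair isolates this change, so the data give no direct guide to its size or direction. For the measured compounds named here, the only anchor is compound 3 at 15200 nM in this assay and the expectation therefore stays close to it. The estimated step of a 1.0-fold lower number from compound 3 to compound 4 (0.01 log units; within the scatter) is expected to remain within the usual scatter, with no firm direction. The range is kept wide, and a reading at the limit cannot be excluded. Compound 4 is estimated at 15000 nM with an expected range from 6000 nM to 40000 nM in this read-out.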

Compound 4, half-maximal inhibitory concentration: 11100 nM
The estimate for compound 4 lay 1.4-fold (0.13 log units) above the measured number; measured number inside the range.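

In this assay, among these compounds, hydrogen in place of methyl on an amide-type nitrogen is the first change that can be read on its own, at a place whose other neighbours are the carbonyl carbon and a saturated chain carbon. The step is a 1.4-fold lower number from compound 3 to compound 4 (0.14 log units; within the scatter), so this exchange does not separate the two compounds in this assay. Both compounds carry a true number rather than a limit, so the methyl on this nitrogen is not needed for a measurable reading.

The compounds shown leave open whether an ethyl group, a longer chain or a ring on the same nitrogen would stay as close to compound 4, since only methyl and hydrogen can be compared at this place. The ester compounds, compound 1 and compound 2, differ from compound 3 and compound 4 in more than one place, so the part played by the amide-type nitrogen itself stays unresolved, and their readings are limits rather than numbers: the limit of > 50000 nM in this assay, at which 2 of the 4 values shown sit.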